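The source may hold more compounds than are shown below. What is called first, only, known or untested is meant among the compounds shown, and "the series" means these compounds.

Working notes on the amide series built on the shared core of compound 1 `CC(C)C(C(N)=O)c1ccc(Cl)cc1`, read in a functional assay on CHO cells for agonist activity at Free fatty acid receptor 2 (Homo sapiens), read by cAMP accumulation; on this read-out lower numbers stand for smaller maximal responses and higher numbers for larger maximal responses. Compound 1 gives only a limit, < 30%, in this assay. the limit of < 30% in this assay, at which 1 of the 3 values shown sits, is the single limit among the three values shown. Compound 2 `CC(C)C(C(=O)Nc1ncccn1)c1ccc(Cl)cc1` gives 50% in this assay, and compound 3 `CC(C)C(C(=O)Nc1cnccn1)c1ccc(Cl)cc1` gives 115%. Compound 3 thus stands highest of the two numbers shown, with compound 2 nearest and the step of a number 65 percentage points higher from compound 2 to compound 3 (beyond the scatter) beyond the scatter. The steps of a number at least 20 percentage points higher from compound 1 to compound 2 (beyond the scatter) and a number at least 85 percentage points higher from compound 1 to compound 3 (beyond the scatter) show that either heteroaryl group on the amide-type nitrogen raises the maximal response above the unsubstituted amide.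

Compound 4 `CC(C)C(C(=O)Nc1nnn[nH]1)c1ccc(Cl)cc1` is not yet measured. It differs from compound 3 by 1H-tetrazol-5-yl in place of pyrazin-2-yl on an amide-type nitrogen. Going by the values given here, the measured steps bear on it only loosely: they show that the aryl group on the amide-type nitrogen moves the maximal response over a wide span, as in a number 65 percentage points higher from compound 2 to compound 3 (beyond the scatter), but no measured compound carries a five-membered ring there. A step within the scatter cannot be ruled out, nor a fall toward compound 2. For compound 4 the maximal response in this assay is expected at 70%, with a range from 20% to 120%. The step of a number 45 percentage points lower from compound 3 to compound 4 (beyond the scatter) is expected to be downward and of moderate size, with wide uncertainty.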

Compound 4, largest response reached (reported as efficacy), in percent of the reference or control that the assay uses: < 30%
Compound 4 gave a limit, no number; the forecaster's own chance of this, stated with the estimate: 15%; middle value at least 40 percentage points from the limit.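

In this assay, 1H-tetrazol-5-yl, the only five-membered ring shown on the amide-type nitrogen, does not keep the response of the six-membered rings: the change gives a number at least 85 percentage points lower from compound 3 to compound 4 (beyond the scatter), and against pyrimidin-2-yl it gives a number at least 20 percentage points lower from compound 2 to compound 4 (beyond the scatter). The rise seen with pyrimidin-2-yl and pyrazin-2-yl therefore does not extend to every aromatic ring at this position, and compound 4 is the compound that goes against that earlier reading. Compound 4 shares its limit with compound 1, and the step between those two cannot be read: the limit of < 30% in this assay, at which 2 of the 4 values shown sit.

The swap from pyrazin-2-yl to 1H-tetrazol-5-yl changes ring size, the count of hetero atoms and the hydrogen-bond donors all at once, and the compounds shown cannot separate these changes from one another. Still open, as far as these compounds go, is how phenyl, pyridin-2-yl or a five-membered ring with fewer hetero atoms, such as thiazol-2-yl, would read on the same nitrogen, and whether a carboxylic acid on the amide-type nitrogen's aryl group would follow compound 3 or compound 4.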